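Methyl to Trifluoromethyl on the Sulfonamide Aryl Ring

The source may hold more compounds than are shown below. What is called first, only, known or untested is meant among the compounds shown, and "the series" means these compounds.

Of the compounds shown here, two have so far been tested in a functional assay on SK-MEL-28 cells (Homo sapiens) for cytotoxicity, read by MTT assay; on this read-out higher numbers stand for weaker inhibition and lower numbers for stronger inhibition. Compound 1 `O=S(=O)(NCCCNc1nccc(-c2c(-c3cccc(F)c3)nc3sccn23)n1)c1ccc(Br)cc1` gives 9400 nM. Among the measured compounds shown here, compound 2 `Cc1ccc(S(=O)(=O)NCCCNc2nccc(-c3c(-c4cccc(F)c4)nc4sccn34)n2)cc1` gives 9500 nM, and it stands alongside compound 1, its only neighbour on this read-out, with the two numbers inside the usual scatter. For the measured compounds named here, the single step between them, a 1.0-fold higher number from compound 1 to compound 2 (0.00 log units; within the scatter), exchanged one group on the aromatic carbon far from the shared core without moving the number.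

Compound 3 `O=S(=O)(NCCCNc1nccc(-c2c(-c3cccc(F)c3)nc3sccn23)n1)c1ccc(C(F)(F)F)cc1` has not yet been measured. It differs from compound 2 by trifluoromethyl in place of methyl on an aromatic carbon. Going by the values given here, the only comparison that bears on this change is the earlier exchange at the same aromatic carbon, which gave a 1.0-fold higher number from compound 1 to compound 2 (0.00 log units; within the scatter). Because that step was a 1.0-fold higher number from compound 1 to compound 2 (0.00 log units; within the scatter), the step of a 1.1-fold lower number from compound 2 to compound 3 (0.02 log units; within the scatter) is expected to be small, with no direction beyond the scatter. Compound 3 is therefore estimated at 9000 nM, within a range from 4000 nM to 20000 nM.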

Compound 3, half-maximal inhibitory concentration: 11700 nM
Compound 3: the middle estimate sits 1.3-fold (0.11 log units) below what was measured; the range from low to high includes it.
By their numbers in this assay, from the lowest: compounds 1, 2 and 3 (each within the scatter of the next).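

In this assay, the exchange of methyl for trifluoromethyl, which takes this place on the ring from 1 heavy atom to 4 heavy atoms, gives a 1.2-fold higher number from compound 2 to compound 3 (0.09 log units; within the scatter) and stays within the scatter. Among the compounds shown here, the comparison with the bromo group gives a 1.2-fold higher number from compound 1 to compound 3 (0.10 log units; within the scatter) and also stays within the scatter, so bromo, methyl and trifluoromethyl can now all be read as equivalent at this aromatic carbon in these three compounds, whereas the earlier pair covered only two groups. No measurement available here explains why the number holds steady across these groups.

The compounds shown leave open whether an amine, a carboxylic acid or a longer chain on the same carbon would shift the number beyond the scatter. They also leave open whether any group at this place can do so, since all three compounds lie within the scatter of one another.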